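Notes on a methyl shift within the shared core

The source may hold more compounds than are shown below. What is called first, only, known or untested is meant among the compounds shown, and "the series" means these compounds.

Three compounds have so far been run in a functional assay on DLA cells (Mus musculus) for cytotoxicity, read by MTT assay, with a stated time of 48 h; a lower number here means a stronger inhibitor, a higher number a weaker inhibitor. Compound 1 `Cc1ccc(C(=O)c2ccc(OCC(=O)Nc3nc(-c4ccccc4)cs3)c(C)c2)cc1` gives 26400 nM. Compound 2 `COc1ccc(-c2csc(NC(=O)COc3ccc(C(=O)c4ccc(C)cc4)cc3C)n2)cc1` gives 17200 nM, and compound 3 `Cc1cc(C(=O)c2ccccc2)cc(C)c1OCC(=O)Nc1nc(-c2ccccc2)cs1` gives 19400 nM. Compound 1 carries the highest of the three numbers, but its separation from compound 3 and from compound 2 each lies within the scatter, so the three are not told apart by these data. Within the data shown here, the only single-point step measured, a 1.5-fold lower number from compound 1 to compound 2 (0.19 log units; within the scatter), adds a methoxy on an aromatic carbon and stays within the scatter; it does not involve the ring that is exchanged here.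

Compound 4 `Cc1cc(C(=O)c2ccccc2C)ccc1OCC(=O)Nc1nc(-c2ccccc2)cs1` is not yet measured. It differs from compound 1 by 2-methylphenyl in place of 4-methylphenyl on a carbonyl carbon. Among the measured compounds shown here, no measured step addresses the methyl position on the ring attached to the carbonyl, and compound 3 differs from compound 1 in more than one place, so it gives no clean reading. With nothing in the data pointing either way, the step from compound 1 to compound 4 is expected to stay within the scatter, estimated at a 1.0-fold lower number from compound 1 to compound 4 (0.01 log units; within the scatter). Compound 4 is therefore expected to give about 26000 nM in this assay, with a range from 12000 nM to 55000 nM.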

Compound 4, half-maximal inhibitory concentration: 23100 nM
Compound 4: middle estimate off by 1.1-fold (0.05 log units), on the high side; the measured number falls inside the stated range.
By their numbers in this assay, from the lowest: compounds 2, 3, 4 and 1 (each within the scatter of the next).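

In this assay, 2-methylphenyl in place of 4-methylphenyl on a carbonyl carbon now has a direct reading (a 1.1-fold lower number from compound 1 to compound 4 (0.06 log units; within the scatter)). Compound 1 and compound 4 have the same atoms, joined differently, so this pair isolates the methyl placement on the ring attached to the carbonyl, and the assay does not tell the two placements apart. No measured evidence on this change is available to account for the result.

Only these two methylphenyl groups are shown on this carbonyl carbon, so the reading holds for this pair alone. On these data alone, it remains open whether another group on that ring, such as an amine or a carboxylic acid, would give a step beyond the scatter, and whether the methyl exchange would read the same alongside the methoxy of compound 2.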